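This account rests on a few compounds, and the source may have more. Where it says the series, first, only, none or still open, it means among the compounds named here.

Series notes

Compound 1 `Cc1ccc(C(/C=C/c2ccc(F)cc2)=N\Nc2nncc3ccccc23)cc1`: 0.55 nM
Compound 2 `Cc1cc(NS(=O)(=O)c2ccc(Nc3nncc4ccccc34)cc2)no1`: 4.4 nM
Compound 3 `C(=C/c1ccccc1)\C(=N\Nc1nncc2ccccc12)c1ccccc1`: 0.33 nM

In a functional assay on SF-295 cells (Homo sapiens) for antiproliferative activity, read by sulforhodamine B assay, with a stated time of 72 h (on this read-out lower numbers stand for stronger inhibition and higher numbers for weaker inhibition), compound 2 gives the highest of the three numbers. The nearest number comes from compound 1, and that gap lies beyond the scatter; the furthest comes from compound 3, also beyond the scatter. Within the data shown here, no two measured compounds differ in a single place, so no measured step is available to guide the change. Compound 4 `O=S(=O)(Nc1ncccn1)c1ccc(Nc2nncc3ccccc23)cc1` differs from compound 2 in one place: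

pyrimidin-2-yl in place of 5-methyl-1,2-oxazol-3-yl on a sulfonamide nitrogen

Both groups are six-heavy-atom aromatic rings bearing two hetero atoms, as counted. Without a comparable measured step, the step of a 1.1-fold higher number from compound 2 to compound 4 (0.06 log units; within the scatter) is expected to be small, probably within the scatter. Compound 4 is accordingly expected to give 5 nM (range 1.5 nM to 16 nM).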

Compound 4, half-maximal inhibitory concentration: 7.6 nM
Compound 4: the middle estimate sits 1.5-fold (0.18 log units) below what was measured, and the stated range covers the measured number.
By their numbers in this assay, from the lowest: compounds 3 and 1 (each within the scatter of the next); then compounds 2 and 4 (each within the scatter of the next).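

In this assay, pyrimidin-2-yl in place of 5-methyl-1,2-oxazol-3-yl on a sulfonamide nitrogen gives a 1.7-fold higher number from compound 2 to compound 4 (0.24 log units; within the scatter). Among these compounds, this is the first measured single-place step, and it shows that, for this pair, a six-membered aromatic ring and a five-membered one cannot be told apart on this read-out. No available measurement accounts for this result.

Still open, on these data alone, is what a methyl group or an unsubstituted phenyl ring on the same nitrogen would give. As far as these compounds go, whether a non-aromatic amine-bearing chain there would depart from this pair beyond the scatter also remains open.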